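The compounds below may be only part of what the source reports. "The series", "measured", "known", "first", "only" and "open" are said of these compounds alone.

Measured so far:
compound 1 `CNC(=O)c1cc(Oc2ccc(NC(=O)c3cc(-c4ccc(F)cc4)ncn3)cc2F)ccn1`: > 100000 nM
compound 2 `CNC(=O)c1cc(Oc2ccc(NC(=O)c3nccc(-c4cccc(Cl)c4)n3)cc2)ccn1`: > 100000 nM

Both numbers come from a functional assay on A549 cells (Homo sapiens) for cytotoxicity, read by MTT assay, with a stated time of 72 h; on this read-out lower numbers stand for stronger inhibition and higher numbers for weaker inhibition. In this assay compound 1 gives only a limit of the assay, > 100000 nM, and no number inside the measurable range. Compound 2 likewise stops at a limit, > 100000 nM. Within the data shown here, compound 1 therefore stands at the limit of > 100000 nM in this assay, at which 2 of the 2 values shown sit; with nothing but limits on hand, no step between measured compounds can be drawn, and no direction of change is known.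

Compound 3 `CNC(=O)c1cc(Oc2ccc(NC(=O)c3cc(-c4ccc(C)cc4)ncn3)cc2F)ccn1` has not yet been measured. It differs from compound 1 by methyl in place of fluoro on an aromatic carbon. One heavy atom leaves and one enters, with no change in ring count, donors, acceptors or charge. Since both shown values sit at the limit, the change is expected to give a step from compound 1 to compound 3 of a number no higher from compound 1 to compound 3 (the limit leaves the size open), that is none beyond the scatter, in either direction. The expected value for compound 3 in this assay is 100000 nM, with a range from 30000 nM to 300000 nM, and the most likely outcome is again a limit rather than a number.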

Compound 3, half-maximal inhibitory concentration: 13200 nM
Compound 3: middle estimate off by 7.6-fold (0.88 log units), on the high side; the whole stated range lies above it.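

In this assay, the 4-fluorophenyl to 4-methylphenyl change gives an at least 7.5-fold lower number from compound 1 to compound 3 (0.87 log units; beyond the scatter), the first one-place change shown that brings a value inside the measurable range. The aromatic position para to a large group therefore matters to this read-out, even though one heavy atom leaves, one enters, and the counts of rings, donors, acceptors and charge stay the same. The value of compound 1 is a limit, so the step has a lower bound but no known full size, and limits remain the majority of the data: the limit of > 100000 nM in this assay, at which 2 of the 3 values shown sit.

The compounds shown leave open whether ethyl, methoxy or an amine at the same position would give a number of the same order as compound 3 or return to the limit, and so whether methyl itself or simply the absence of fluoro goes with the change. They also leave open whether methyl would have a similar effect on compound 2, which differs from compound 1 in more than one place and cannot be compared with it.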